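The source may report more compounds than this note shows. Statements on the series, on what has been measured and on what is new or still open speak of the compounds shown alone.

The measured compounds:

Compound 1 `O=C(CN1CCC(Cc2ccccc2)CC1)Nc1ccc(C(=O)/C=C/c2cn(Cc3ccc(Br)cc3)nn2)cc1`: in a functional assay on A549 cells (Homo sapiens) for inhibition, read by MTT assay (a lower number here means a stronger inhibitor, a higher number a weaker inhibitor), compound 1 gives 40000 nM
Compound 2 `CC(C)(C)OC(=O)N1CCN(CC(=O)Nc2ccc(C(=O)/C=C/c3cn(Cc4ccc(Br)cc4)nn3)cc2)CC1`: compound 2 gives 38400 nM
Compound 3 `CCCCCCCCCCn1cc(/C=C/C(=O)c2ccc(NC(=O)CN3CCC(Cc4ccccc4)CC3)cc2)nn1`: compound 3 gives 67700 nM

All three numbers lie close together, and compound 2 and compound 1 sit within the scatter of one another, so no order among them is claimed. Compound 3 is made from compound 1 by one change, (nonyl in place of 4-bromophenyl on a saturated chain carbon bound to an aromatic nitrogen), and the step is a 1.7-fold higher number from compound 1 to compound 3 (0.23 log units; within the scatter).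

Compound 4 `CCCCCCCCCCn1cc(/C=C/C(=O)c2ccc(NC(=O)CN3CCN(C(=O)OC(C)(C)C)CC3)cc2)nn1` has not yet been measured in this assay. It is related to compound 2 in the same way that compound 3 is related to compound 1: the change is nonyl in place of 4-bromophenyl on a saturated chain carbon bound to an aromatic nitrogen, and the place is the same in both pairs. How the core of compound 2 differs from the core of compound 1 is not broken down here.

Because the step of a 1.7-fold higher number from compound 1 to compound 3 (0.23 log units; within the scatter) stayed within the scatter, the same change on the core of compound 2 is expected to move the number by a similar, small amount, so the expected step is a 1.6-fold higher number from compound 2 to compound 4 (0.19 log units; within the scatter). The expectation rests on a single earlier pair only, and on the core of compound 1 rather than that of compound 2, which leaves the estimate loose. Compound 4 is therefore estimated at 60000 nM in this assay, with a plausible range from 30000 nM to 130000 nM.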

Compound 4, half-maximal inhibitory concentration: 45400 nM
Estimate against measurement, compound 4: 1.3-fold (0.12 log units) above; the range from low to high includes it.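

In this assay, putting nonyl in place of 4-bromophenyl on a saturated chain carbon bound to an aromatic nitrogen gives a 1.2-fold higher number from compound 2 to compound 4 (0.07 log units; within the scatter), so on the core of compound 2, as on the core of compound 1, the step stays within the scatter. Set side by side, the two steps do not differ by more than two such steps can be expected to scatter: the same change on two cores in this assay, a 1.7-fold higher number (0.23 log units; within the scatter) from compound 1 to compound 3 and a 1.2-fold higher number (0.07 log units; within the scatter) from compound 2 to compound 4, 1.4-fold (0.16 log units) apart, within the scatter of two such steps. Within this series, the change therefore carries from one core to the other without a readable shift in the number, but two pairs cover only two cores, and neither step can be told from no change at all, so this does not show that the change would behave the same way on any further core.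

What the compounds shown leave open is whether anything placed at this position can move the number beyond the scatter, for example a shorter chain, a longer chain ending in an amine or a carboxylic acid, or a phenyl ring bearing a different halogen such as chlorine or fluorine. They also leave open whether the same replacement would stay as small on a core carrying a free amine in place of the groups present in compound 1 and compound 2.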